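The source may hold more compounds than are shown below. What is called first, only, known or untested is meant among the compounds shown, and "the series" means these compounds.

Compound 1 `Cc1cc(Nc2cc(-c3ccccc3)[nH]n2)n2nc(SCC3CCCCC3)nc2n1` carries a cyclohexyl group on a saturated chain carbon bound to a sulfur. In a functional assay on PC-9 cells (Homo sapiens) for inhibition, read by MTT assay, with a stated time of 72 h (on this read-out lower numbers stand for stronger inhibition and higher numbers for weaker inhibition), compound 1 gives > 50000 nM, which is a limit of the assay rather than a number (the limit of > 50000 nM in this assay, at which 1 of the 3 values shown sits). Compound 4 `Cc1cc(Nc2cc(-c3ccccc3)[nH]n2)n2nc(SCc3cccc4ccccc34)nc2n1` differs from it in one place: naphthalen-1-yl in place of cyclohexyl on a saturated chain carbon bound to a sulfur. Two measured changes at the same spot bear on this. Compound 2 `Cc1cc(Nc2cc(-c3ccccc3)[nH]n2)n2nc(SCCCc3ccccc3)nc2n1` gives 5030 nM and compound 3 `Cc1cc(Nc2cc(-c3ccccc3)[nH]n2)n2nc(SCc3nc4ccccc4[nH]3)nc2n1` gives 4840 nM; the steps were an at least 9.9-fold lower number from compound 1 to compound 2 (0.99 log units; beyond the scatter) and an at least 10-fold lower number from compound 1 to compound 3 (1.01 log units; beyond the scatter), while a 1.0-fold lower number from compound 2 to compound 3 (0.02 log units; within the scatter). Both aromatic replacements for cyclohexyl brought a large drop, so a drop of similar size is expected here, namely an at least 10-fold lower number from compound 1 to compound 4 (1.00 log units; beyond the scatter). Compound 4 is therefore estimated at 5000 nM, within 1500 nM to 20000 nM.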

Compound 4, half-maximal inhibitory concentration: 3950 nM
The estimate for compound 4 lay 1.3-fold (0.10 log units) above the measured number, within the range that was stated.
By their numbers in this assay, from the lowest: compounds 4, 3 and 2 (each within the scatter of the next). At a limit, above all of these: compound 1.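

Naphthalen-1-yl, made of carbon only, in place of cyclohexyl gives an at least 12-fold lower number from compound 1 to compound 4 (1.10 log units; beyond the scatter). This size is only a bound, as compound 1 stands at a limit of the assay and not at a number: the limit of > 50000 nM in this assay, at which 1 of the 4 values shown sits. This third aromatic group is level with the other two replacements, with a 1.2-fold lower number from compound 3 to compound 4 (0.09 log units; within the scatter) and a 1.3-fold lower number from compound 2 to compound 4 (0.10 log units; within the scatter), both within the scatter, so a ring containing only carbon serves here as well as 1H-benzimidazol-2-yl.

Still open, on these data alone, is whether an amine or a carboxylic acid at this place would give a clearly lower number. A longer chain carrying naphthalen-1-yl is equally untested by the compounds shown.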